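The compounds below may be only part of what the source reports. "The series", "measured", "known", "first", "only" and "open" are said of these compounds alone.

Of the compounds shown here, three have been measured in a functional assay for agonist activity at G protein-coupled receptor 88 (Homo sapiens), read by HTRF and cAMP accumulation; a lower number here means that less compound is needed, a higher number that more compound is needed for the effect. Compound 1 `CC[C@H](C)[C@H](N)CN(C(=O)[C@@H]1C[C@H]1c1nc(C)cs1)c1ccc(-c2ccccc2)cc1` gives 730 nM, compound 2 `CC(C)C[C@H](N)CN(C(=O)[C@@H]1C[C@H]1c1ccccc1)c1ccc(-c2cccc(F)c2)cc1` gives 2100 nM, and compound 3 `CCc1ccc(-c2ccc(N(C[C@@H](N)[C@@H](C)CC)C(=O)[C@@H]3C[C@H]3c3ccccc3)cc2)cc1` gives 44 nM. Compound 3 stands lowest: its number lies well below that of compound 1 and further still below that of compound 2, both gaps beyond the usual scatter, so it is the most potent of the three. Compound 4 `CCOc1ccc(-c2ccc(N(C[C@@H](N)[C@@H](C)CC)C(=O)[C@@H]3C[C@H]3c3ccccc3)cc2)cc1` differs from compound 3 in one place: ethoxy in place of ethyl on an aromatic carbon. For the measured compounds named here, no measured pair shows this exchange, so nothing in the data tells its effect directly. The step from compound 3 to compound 4 is expected to be small, a 1.3-fold higher number from compound 3 to compound 4 (0.10 log units; within the scatter), with no clear direction beyond the scatter. Compound 4 is estimated at 55 nM in this assay, with a range from 20 nM to 150 nM.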

Compound 4, half-maximal effective concentration: 90 nM
Beside the measured number, compound 4's estimate is 1.6-fold (0.21 log units) below it, within the range that was stated.
By their numbers in this assay, from the lowest: compound 3; then compound 4; then compound 1; then compound 2.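

Exchanging ethyl for ethoxy on this aromatic carbon, para to a large group, gives a 2.0-fold higher number from compound 3 to compound 4 (0.31 log units; beyond the scatter), a modest step just beyond the scatter. For the compounds shown here, this is the first direct reading of a change at this position, since the earlier compounds differ from each other in more than one place. Nothing measured here bears on the reason for this step.

The compounds shown leave open whether the oxygen or the extra heavy atom matters more. A propyl group, with a carbon in place of that oxygen, would separate the two, while a methoxy group would test a shorter chain that keeps the oxygen.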